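The source may report more compounds than this note shows. Statements on the series, on what has been measured and on what is new or still open speak of the compounds shown alone.

Working notes on the series. Among the compounds with values here, compound 1 `CCCCCCCCCO[C@@H]1[C@@H](N)[C@@H](O[C@H]2[C@H](O)[C@@H](O)[C@H](N)C[C@@H]2N)O[C@H](CN)[C@H]1OCCCCCCCCC` has been read in a toxicity assay on the whole organism (J774 cells) for cytotoxicity, with Mus musculus as the target, read by MTT assay, with a stated time of 24 h, tested at 30 uM; on this read-out higher numbers stand for a weaker effect at the one concentration tested and lower numbers for a stronger effect; in this assay compound 1 gives 48.6%, the second highest of the three numbers so far. Compound 2 `CCCCCCCCCO[C@@H]1[C@@H](N)[C@@H](O[C@H]2[C@H](O)[C@@H](OCCCCCCCCC)[C@H](N)C[C@@H]2N)O[C@H](CN)[C@H]1O` gives 38.8% in this assay, a gap to compound 1 that lies within the scatter. Compound 3 `C=CCO[C@H]1O[C@H](CN)[C@@H](O)[C@H](O)[C@H]1N` gives 82.1% in this assay, a number beyond the scatter higher than that of compound 1. Compound 4 `CCCCCCCCCO[C@@H]1[C@@H](N)[C@@H](OC[C@@H](O)CN)O[C@H](CN)[C@H]1OCCCCCCCCC` is not yet measured. It differs from compound 1 in one place: 3-amino-2-hydroxypropyl in place of 4,6-diamino-2,3-dihydroxycyclohexyl on an oxygen on a saturated carbon. Within the data shown here, no measured pair isolates this change, so the size of the step is uncertain; in this assay it is expected to be small, in no direction beyond the scatter, the estimated step being a number 1.4 percentage points higher from compound 1 to compound 4 (within the scatter). Compound 4 is expected to give about 50% in this assay, with a range from 30% to 72%.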

Compound 4, a percentage reported as activity, at one concentration (the size of the read-out at that concentration, not a potency): 7.2%
Beside the measured number, compound 4's estimate is 42.8 percentage points above it; the measured number lies below the stated range.
By their numbers in this assay, from the lowest: compound 4; then compounds 2 and 1 (each within the scatter of the next); then compound 3.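

In this assay, 3-amino-2-hydroxypropyl in place of 4,6-diamino-2,3-dihydroxycyclohexyl on this oxygen gives a number 41.4 percentage points lower from compound 1 to compound 4 (beyond the scatter), a stronger effect at the one concentration tested. Within the data shown here, this position is therefore sensitive to the group it carries, which no earlier pair could show. Nothing available accounts for the size of this step.

Still open, from the compounds shown here alone, is whether the loss of the ring or the loss of its amines and hydroxyls carries the step. Going by these compounds, how a 3-aminopropyl or a plain cyclohexyl group on this oxygen would read also remains unknown.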